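The source may report more compounds than this note shows. Statements on the series, on what has been measured and on what is new or still open speak of the compounds shown alone.

Measured so far in an ADME assay on HepG2 cells (Homo sapiens) for cytotoxicity, read by luminescence, CellTiter-Glo and ATP content, with a stated time of 72 h; a lower number here means that less compound is needed, a higher number that more compound is needed for the effect:

Compound 1 `COc1ccc(-c2ccc3c(NCCCNCc4cccc(OC)c4O)ccnc3c2)cc1`: 1600 nM
Compound 2 `CCC(CC)c1ccc2c(NCCCNCc3ccco3)ccnc2c1`: 6760 nM

Compound 1 holds the lower of these two numbers, and the number for compound 2 is higher by more than the usual scatter of repeated measurements. Among the measured compounds shown here, two compounds make a very short series, and they differ in more than one place, so no measured step isolates the effect of a single change.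

Compound 3 `COc1cccc(CNCCCNc2ccnc3cc(Cc4cccc(C(F)(F)F)c4)ccc23)c1O` is still to be measured. It keeps the rest of compound 1 but carries 3-(trifluoromethyl)benzyl in place of 4-methoxyphenyl on an aromatic carbon. For the measured compounds named here, nothing measured so far tests this swap, so the expectation for this assay is a small step, probably none beyond the scatter. A slight lean toward a higher number rests only on compound 1 at 1600 nM being the lower of just two values. The estimated change is a 1.4-fold higher number from compound 1 to compound 3 (0.14 log units; within the scatter). For compound 3 the expected value is 2200 nM, with an estimated range from 800 nM to 6000 nM.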

Compound 3, half-maximal effective concentration: 1720 nM
Estimate against measurement, compound 3: 1.3-fold (0.11 log units) above; low and high end bracket the measured number.
By their numbers in this assay, from the lowest: compounds 1 and 3 (each within the scatter of the next); then compound 2.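

Among the compounds shown here, replacing 4-methoxyphenyl with 3-(trifluoromethyl)benzyl on this aromatic carbon gives the first single change that can be read in this assay, and the result is a 1.1-fold higher number from compound 1 to compound 3 (0.03 log units; within the scatter), a step within the scatter. The two groups are far from identical: the entering one has 11 heavy atoms against 8, carries fluorine instead of oxygen and has 0 hydrogen-bond acceptors against 1, yet this assay does not separate compound 1 from compound 3, so at this position, at least for this one pair, the number does not follow those differences. No measurement at hand bears on why these two groups read alike.

As far as these compounds go, a single pair cannot show whether any group at this position would leave the number within the scatter, so it remains open whether a much smaller or quite different group, such as a hydroxyl, an amine or a carboxylic acid, would do the same. Compound 2 differs from compound 1 in more than one place, so which of its differences accounts for its separate standing in this series also remains open.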